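This account rests on a few compounds, and the source may have more. Where it says the series, first, only, none or still open, it means among the compounds named here.

In a functional assay on HepG2 cells (Homo sapiens) for inhibition, read by sulforhodamine B assay, with a stated time of 74 h (a lower number here means a stronger inhibitor, a higher number a weaker inhibitor), compound 1 (`O=C1C=CC2(C=C1)OCC(=O)N2S(=O)(=O)c1ccccc1`) gives > 10000 nM, which is a limit of the assay. Compound 2 (`O=C1C=CC2(C=C1)OCC(=O)N2S(=O)(=O)c1ccc([N+](=O)[O-])cc1`) gives > 10000 nM, also a limit, so it has no exact standing on the numbers shown. Compound 3 (`O=C1C=CC2(C=C1)OCC(=O)N2S(=O)(=O)c1ccc(N2CCCC2=O)cc1`) has 2-oxopyrrolidin-1-yl in place of nitro on an aromatic carbon, para to a large group: 2-oxopyrrolidin-1-yl in place of nitro on an aromatic carbon. Going by the values given here, the only measured step that bears on this is a step that the two limits leave unreadable from compound 1 to compound 2, and the evidence is the limit of > 10000 nM in this assay, at which 2 of the 2 values shown sit. That step has no readable size, so no change beyond the scatter is expected in this assay. The expected step is a step that the limit leaves unreadable from compound 2 to compound 3. Compound 3 is estimated at 12000 nM, within an expected range of 3000 nM to 40000 nM.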

Compound 3, half-maximal inhibitory concentration: > 10000 nM
Compound 3: no number, only a limit; the forecaster's own chance of this, stated with the estimate: 70%; the middle value is on the limit's open side.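

Going by these compounds alone, compound 3 also gives only a limit, so no step among compound 1, compound 2 and compound 3 can be read: the limit of > 10000 nM in this assay, at which 3 of the 3 values shown sit. Going by these compounds, whether the group on the aromatic ring changes inhibition in this assay stays open.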